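Fluorophenyl variation on the shared core: toward compound 4

The compounds below may be only part of what the source reports. "The series", "measured", "known", "first", "only" and "open" are said of these compounds alone.

Measured so far in a functional assay on ileum for antagonist activity at histamine H1 receptor (Cavia porcellus); a higher number here means weaker binding, a lower number tighter binding:
compound 1 `N=C(NCCCc1c[nH]cn1)NCCC(c1ccc(F)cc1)c1ccccn1` — 22.4 nM
compound 2 `N=C(NCCCc1c[nH]cn1)NCCC(c1cccc(F)c1)c1ccccn1` — 158 nM
compound 3 `N=C(NCCCc1c[nH]cn1)NCCC(c1cccc(C(F)(F)F)c1)c1ccccn1` — 525 nM

Compound 3 stands highest of the three numbers. The steps up to it are a 3.3-fold higher number from compound 2 to compound 3 (0.52 log units; beyond the scatter) and a 23-fold higher number from compound 1 to compound 3 (1.37 log units; beyond the scatter), both beyond the scatter, the first modest and the second large. The remaining step, a 7.1-fold higher number from compound 1 to compound 2 (0.85 log units; beyond the scatter), is also modest and beyond the scatter.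

Compound 4 `N=C(NCCCc1c[nH]cn1)NCCC(c1cc(F)cc(F)c1)c1ccccn1` differs from compound 3 in one place: 3,5-difluorophenyl in place of 3-(trifluoromethyl)phenyl on a saturated chain carbon bound to an aromatic carbon and a saturated chain carbon.

Of the measured steps, a 3.3-fold higher number from compound 2 to compound 3 (0.52 log units; beyond the scatter) bears most directly on this change, since it too exchanges trifluoromethyl for fluoro on an aromatic carbon; read in reverse it points to a lower number for compound 4 than for compound 3. For the measured compounds named here, the second fluoro entering with 3,5-difluorophenyl has no measured counterpart in this set, so its contribution is undetermined; compound 1 and compound 2 show only that the two single-fluoro patterns differ by a 7.1-fold higher number from compound 1 to compound 2 (0.85 log units; beyond the scatter). A modest downward step is therefore expected, roughly the reverse of the trifluoromethyl-to-fluoro step, with the second fluoro left as the open term.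

In this assay compound 4 is expected at about 200 nM, within 70 nM to 600 nM, meaning an expected step of a 2.6-fold lower number from compound 3 to compound 4 (0.42 log units; beyond the scatter).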

Compound 4, dissociation constant: 275 nM
The estimate for compound 4 lay 1.4-fold (0.14 log units) below the measured number, within the range that was stated.
By their numbers in this assay, from the lowest: compound 1; then compounds 2, 4 and 3 (each within the scatter of the next, the first and the last beyond it).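

In this assay the swap of 3-(trifluoromethyl)phenyl for 3,5-difluorophenyl on the saturated chain carbon gives a 1.9-fold lower number from compound 3 to compound 4 (0.28 log units; within the scatter) and so does not separate the two groups, while the added fluoro gives a 1.7-fold higher number from compound 2 to compound 4 (0.24 log units; within the scatter) and does not separate compound 4 from its single-fluoro neighbour either. For the compounds shown here, compound 4 therefore sits unresolved from both compounds of the one step that was beyond the scatter among the substituted groups compared here, a 3.3-fold higher number from compound 2 to compound 3 (0.52 log units; beyond the scatter) and the ordering of those three groups remains only partly settled. The clear new separation is a 12-fold higher number from compound 1 to compound 4 (1.09 log units; beyond the scatter) which leaves 4-fluorophenyl set apart from all three other groups at this place, though no measurement in hand bears on the reason for any of these differences.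

Still open, from the compounds shown here alone, is whether any other group on this carbon, such as a chlorophenyl, a methoxyphenyl or an aminophenyl, comes close to compound 1 at 22.4 nM in this read-out. Also open, going by these compounds, is whether the same steps hold when the shared core carries a longer chain, and whether a second 4-substituted group would stay apart from the rest as 4-fluorophenyl does.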